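This account rests on a few compounds, and the source may have more. Where it says the series, first, only, none or still open, it means among the compounds named here.

Measured so far:
- compound 1, `Nc1scc(CN2CCN(c3ccc(F)cc3Cl)CC2)c1C(=O)c1ccc(Cl)cc1`, -6.2%
- compound 2, `Nc1scc(CN2CCN(c3cccc(F)c3)CC2)c1C(=O)c1cccc(C(F)(F)F)c1`, -12%

Both numbers come from a functional assay on CHO cells with adenosine receptor A1 (Homo sapiens) as the target, read by cAMP accumulation and immunoassay, with a stated time of 6 min, tested at 0.1 uM; a higher number here means a weaker effect of the compound at the concentration tested, a lower number a stronger effect. In this assay compound 1 gives -6.2% and compound 2 gives -12%; the two values lie within the usual scatter of each other, so neither compound shows an effect that can be told apart from the other, and both sit close to no effect at all at the concentration used. For the measured compounds named here, no step between measured compounds that differ in one place is available, so nothing is known yet about how a single change on the shared core moves the read-out.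

Compound 3, `Nc1scc(CN2CCN(c3cccc4ccccc34)CC2)c1C(=O)c1ccc(Cl)cc1`, differs from compound 1 in one place: naphthalen-1-yl in place of 2-chloro-4-fluorophenyl on an amine nitrogen in a ring. Since the two measured compounds, with different groups on the same ring nitrogen, both read near zero in this assay, the expected step from compound 1 to compound 3 is a number 1.2 percentage points higher from compound 1 to compound 3 (within the scatter), that is, none beyond the scatter. Compound 3 is therefore expected to give about -5% in this assay, within a range from -25% to 15%.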

Compound 3, a percentage reported as activity, at one concentration (the size of the read-out at that concentration, not a potency): 0%
Beside the measured number, compound 3's estimate is 5 percentage points below it, and the stated range covers the measured number.
By their numbers in this assay, from the lowest: compounds 2, 1 and 3 (each within the scatter of the next, the first and the last beyond it).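

Naphthalen-1-yl in place of 2-chloro-4-fluorophenyl on the ring nitrogen gives, in this assay, a number 6.2 percentage points higher from compound 1 to compound 3 (within the scatter). For the compounds shown here, this is the first single change available at this position, and it shows that two fused aromatic rings of carbon only, with no chlorine or fluorine, cannot be told apart in this read-out from the single ring carrying both of those atoms. At the one concentration tested, this position therefore accepts this exchange of one aromatic group for another without a change beyond the usual scatter, and no measurement is available that would explain the result.

Still open, on these data alone, is whether a group of a different kind on this ring nitrogen, such as a benzyl group, an acetyl group or a short chain ending in a carboxylic acid, would read apart from these aromatic groups in this assay. A single concentration also leaves open whether compound 1 and compound 3 would stay within the scatter of each other at other concentrations.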